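Replacing the aryl group on the sulfur side chain

The source may hold more compounds than are shown below. What is called first, only, known or untested is meant among the compounds shown, and "the series" means these compounds.

Compound 1 `COc1ccc2cc([C@H](C)c3nnc(SCc4c(Cl)cccc4Cl)n3-c3ccc(F)cc3)ccc2c1` gives 216000 nM
Compound 2 `COc1ccc2cc([C@H](C)c3nnc(SCc4c(C)cc(C)cc4C)n3-c3ccc(F)cc3)ccc2c1` gives 43300 nM

In a functional assay on PC-3 cells (Homo sapiens) for cytotoxicity, read by MTT assay (on this read-out lower numbers stand for stronger inhibition and higher numbers for weaker inhibition), compound 2 at 43300 nM has the lower of the two numbers. Compound 3 `COc1cccc(CSc2nnc([C@@H](C)c3ccc4cc(OC)ccc4c3)n2-c2ccc(F)cc2)c1` keeps the shared core but carries 3-methoxyphenyl in place of 2,4,6-trimethylphenyl on a saturated chain carbon bound to a sulfur. Among the compounds with values here, only one measured step changes this same place, namely a 5.0-fold lower number from compound 1 to compound 2 (0.70 log units; beyond the scatter) and it gives the only guide to size. In this assay the expected step, somewhat smaller and toward a higher number, is a 2.1-fold higher number from compound 2 to compound 3 (0.32 log units; beyond the scatter) and rests on that single comparison. Compound 3 is estimated at 90000 nM with an expected range from 25000 nM to 300000 nM in all.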

Compound 3, half-maximal inhibitory concentration: 211000 nM
Beside the measured number, compound 3's estimate is 2.3-fold (0.37 log units) below it, within the range that was stated.
By their numbers in this assay, from the lowest: compound 2; then compounds 3 and 1 (each within the scatter of the next).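

Putting 3-methoxyphenyl on the saturated chain carbon bound to a sulfur gives a 4.9-fold higher number from compound 2 to compound 3 (0.69 log units; beyond the scatter) in this assay and so loses what 2,4,6-trimethylphenyl had gained. Against 2,6-dichlorophenyl, the same group gives a 1.0-fold lower number from compound 1 to compound 3 (0.01 log units; within the scatter) and the two cannot be told apart, which leaves 2,4,6-trimethylphenyl as the only one of the three groups with a lower number. Nothing available explains this difference.

On these data alone, what plain phenyl would give at this place stays open. So does the outcome for an amine, a carboxylic acid or a longer chain there.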